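Compound 4: pyridin-2-yl in place of phenyl

The compounds below may be only part of what the source reports. "The series", "measured", "known", "first", "only" and "open" are said of these compounds alone.

In a functional assay on NCI-H460 cells (Homo sapiens) for inhibition, read by MTT assay, with a stated time of 24 h, tested at 1 ug/mL (a higher number here means more inhibition of growth at the concentration tested, a lower number less inhibition of growth), all three measured compounds give small numbers. Compound 3 (`O=C(CCCCC(S)CCS)Nc1ccccc1`) gives 4.3%. Compound 1 (`O=C(CCCCC(S)CCS)NO`) gives 1.17%. Compound 2 (`O=C(CCCCC1CCSS1)Nc1ccccn1`) gives 0.81%. These values lie within the scatter of each other, so compound 3 cannot be separated from the other two.

Compound 4 (`O=C(CCCCC(S)CCS)Nc1ccccn1`) has not yet been measured and differs from compound 3 in one place: pyridin-2-yl in place of phenyl on an amide-type nitrogen. The new compound therefore has pyridin-2-yl in place of phenyl on an amide-type nitrogen.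

Among the measured compounds shown here, no measured step makes this exact exchange. For the measured compounds named here, the only step available, a number 3.1 percentage points higher from compound 1 to compound 3 (within the scatter), is at the same amide-type nitrogen and stays within the scatter. Compound 2 also carries pyridin-2-yl on an amide-type nitrogen, but on a different core, and its 0.81% offers no direct comparison. Going by the values given here, nothing measured so far points to a change in either direction, so no step beyond the scatter is expected in this assay.

The estimated step is a number 1.3 percentage points lower from compound 3 to compound 4 (within the scatter), which would stay within the scatter. For compound 4 the expected value is 3%, with an estimated range from 0% to 12%.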

Compound 4, percent growth inhibition at one concentration: 2.31%
Compound 4: the middle estimate sits 0.7 percentage points above what was measured; measured number inside the range.
By their numbers in this assay, from the lowest: compounds 2, 1, 4 and 3 (each within the scatter of the next).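

In this assay, the exchange of phenyl for pyridin-2-yl on the amide-type nitrogen now has a direct reading (a number 2 percentage points lower from compound 3 to compound 4 (within the scatter)), and the entering ring nitrogen, counted as a hydrogen-bond acceptor, does not separate the two aromatic groups. The other two comparisons also stay inside the scatter: the open group of 5 heavy atoms in place of the five-membered non-aromatic ring with 2 hetero atoms, on a saturated chain carbon, gives a number 1.5 percentage points higher from compound 2 to compound 4 (within the scatter), and pyridin-2-yl in place of hydroxy on the amide-type nitrogen gives a number 1.1 percentage points higher from compound 1 to compound 4 (within the scatter). No evidence at hand explains why these steps are so small.

From the compounds shown here alone, all the numbers are low and close together at the single concentration tested, so it remains open whether any change at the amide-type nitrogen or in the sulfur-bearing group can produce a step beyond the scatter. A benzyl group or an amine-bearing chain on that nitrogen, or a longer chain leading to the carbonyl carbon, would test this further.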